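Purine series: effect of removing a ring chloro

The source may report more compounds than this note shows. Statements on the series, on what has been measured and on what is new or still open speak of the compounds shown alone.

Measured compounds:
compound 1 `Nc1nc(Cl)c2ncn(Cc3ccccc3CCl)c2n1` — 3390 nM
compound 2 `ClCc1ccccc1Cn1cnc2nc(Cl)nc(Cl)c21` — 14100 nM

In a functional assay on OVCAR-3 cells (Homo sapiens) for cytotoxicity, read by sulforhodamine B assay, with a stated time of 48 h (on this read-out lower numbers stand for stronger inhibition of growth and higher numbers for weaker inhibition of growth), compound 2 gives 14100 nM, the highest of the two numbers; its nearest neighbour is compound 1 with a lower number, a gap beyond the scatter. Compound 3 `ClCc1ccccc1Cn1cnc2ncnc(Cl)c21` is not yet measured. It differs from compound 2 by one change: hydrogen in place of chloro on an aromatic carbon. No single-place step between measured compounds is known here, so the effect of this change rests on no shown pair. Compound 3 is expected to stay close to compound 2, a step of a 1.2-fold higher number from compound 2 to compound 3 (0.08 log units; within the scatter) not beyond the scatter. Compound 3 is therefore estimated at 17000 nM, in the range 6000 nM to 50000 nM.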

Compound 3, concentration for 50% growth inhibition: 2040 nM
For compound 3 the middle estimate is 8.3-fold (0.92 log units) above the measured one, and the stated range ends above it.
By their numbers in this assay, from the lowest: compounds 3 and 1 (each within the scatter of the next); then compound 2.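

In this assay, among the compounds shown here, hydrogen in place of chloro on the aromatic carbon between two ring nitrogen atoms gives a 6.9-fold lower number from compound 2 to compound 3 (0.84 log units; beyond the scatter) and provides the first single-place reading at this position. The position therefore responds to substitution, and here removing the chloro goes with stronger growth inhibition. No available evidence accounts for this step. The compounds shown leave open how a methyl, methoxy or dimethylamino group would read at this position. They also leave open whether replacing the remaining chloro with hydrogen would give a similar step.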